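This account rests on a few compounds, and the source may have more. Where it says the series, first, only, none or still open, it means among the compounds named here.

Series notes, growth inhibition of breast-cancer cells.

Compound 1 `Cc1nc(CCO)cc2nn(-c3ccccc3)cc12` and compound 2 `Cc1nccc2nn(-c3ccccc3)cc12` share a core with compound 3 `c1ccc(-c2cc3nn(-c4ccccc4)cc3cn2)cc1`, and compound 4 `Cc1nc(-c2ccccc2)cc2nn(-c3ccccc3)cc12` is the next member to be run. In a functional assay on MCF7 cells (Homo sapiens) for inhibition, read by fluorescence, with a stated time of 72 h (a higher number here means a weaker inhibitor of growth, a lower number a stronger inhibitor of growth), compound 1 gives > 100000 nM, which is a limit of the assay and not a number. In this assay compound 2 gives > 100000 nM, again a limit. The step that the two limits leave unreadable from compound 1 to compound 2 therefore cannot be sized, because both ends sit at the limit of > 100000 nM in this assay, at which 2 of the 3 values shown sit. In this assay, among the measured compounds shown here, compound 3 gives 4800 nM, the only number so far.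

Compound 4 differs from compound 3 by methyl in place of hydrogen on an aromatic carbon. For the measured compounds named here, no measured step covers this change; the one step on record is unreadable and concerns another group, so it gives no direction. Compounds 1 and 2 carry the methyl but lack the phenyl and sit at the limit, which says nothing about the methyl alone. The expected step of a 1.0-fold higher number from compound 3 to compound 4 (0.02 log units; within the scatter) is none beyond the scatter. Compound 4 is estimated at 5000 nM, expected between 1800 nM and 15000 nM.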

Compound 4, concentration for 50% growth inhibition: 11000 nM
Compound 4: middle estimate off by 2.2-fold (0.34 log units), on the low side; low and high end bracket the measured number.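

In this assay, the position next to the ring nitrogen now has a readable step, with methyl in place of hydrogen: a 2.3-fold higher number from compound 3 to compound 4 (0.36 log units; beyond the scatter). With that methyl held in place, the phenyl group gives a second readable change, in place of hydrogen as an at least 9.0-fold lower number from compound 2 to compound 4 (0.95 log units; beyond the scatter) and in place of 2-hydroxyethyl as an at least 9.0-fold lower number from compound 1 to compound 4 (0.95 log units; beyond the scatter). Both phenyl steps are bounds and not sizes, because compound 1 and compound 2 each stand at a limit of the assay and not at a number: the limit of > 100000 nM in this assay, at which 2 of the 4 values shown sit.

Going by these compounds, the methyl step is known only with the phenyl group present, so its size without that group stays open. Also open, on these data alone, is how an amine or a longer chain at the methyl position, or a carboxylic acid in place of the phenyl group, would move the number.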